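Swapping a piperidine-bearing chain for a pyridinylmethyl group

The source may report more compounds than this note shows. Statements on the series, on what has been measured and on what is new or still open speak of the compounds shown alone.

Of the compounds shown here, three sharing one core have been tested in an assay on HEK293 cells for inhibition of Steryl-sulfatase (Homo sapiens), tested at 1 uM; on this read-out lower numbers stand for a weaker effect and higher numbers for a stronger effect at the one concentration tested. Compound 3 `CN(CCN1CCCCC1)c1cccc(C(=O)N2CCc3ccc(OS(N)(=O)=O)cc3C2)c1` gives 30.8%, which places it second highest of the three. Compound 1 `CCN(Cc1ccccn1)c1cccc(C(=O)N2CCc3ccc(OS(N)(=O)=O)cc3C2)c1` gives 19.9%, so that the change a number 10.9 percentage points higher from compound 1 to compound 3 (beyond the scatter). Compound 2 `CCCN(CCC)c1cccc(C(=O)N2CCc3ccc(OS(N)(=O)=O)cc3C2)c1` gives 54.8%, and the change a number 24 percentage points lower from compound 2 to compound 3 (beyond the scatter). The step from compound 1 to compound 2 is the largest of the set, at a number 34.9 percentage points higher from compound 1 to compound 2 (beyond the scatter).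

Compound 4 `CCN(Cc1cccnc1)c1cccc(C(=O)N2CCc3ccc(OS(N)(=O)=O)cc3C2)c1` has not yet been measured in this assay. It differs from compound 3 as follows: ethyl((pyridin-3-yl)methyl)amino in place of methyl(2-(piperidin-1-yl)ethyl)amino on an aromatic carbon. This is close to reversing the step from compound 1 to compound 3, because a number 10.9 percentage points higher from compound 1 to compound 3 (beyond the scatter) describes what happened when the ethyl((pyridin-2-yl)methyl)amino group of compound 1 was replaced by the chain of compound 3. Within the data shown here, compound 4 carries an ethyl((pyridin-3-yl)methyl)amino group instead, and there is no measured pair that separates the two pyridinylmethyl groups from each other. The most defensible expectation is therefore a modest fall, roughly undoing that earlier rise.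

For compound 4 the estimated value in this assay is 22%, within a range from 10% to 38%, which as a step is expected to be a number 8.8 percentage points lower from compound 3 to compound 4 (within the scatter).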

Compound 4, a percentage reported as inhibition, at one concentration (the size of the read-out at that concentration, not a potency): 33.5%
Compound 4: the middle estimate sits 11.5 percentage points below what was measured; the measured number falls inside the stated range.
By their numbers in this assay, from the lowest: compound 1; then compounds 3 and 4 (each within the scatter of the next); then compound 2.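

In this assay, among these compounds, exchanging pyridin-2-yl for pyridin-3-yl on the same chain, with the rest of the molecule unchanged, gives a number 13.6 percentage points higher from compound 1 to compound 4 (beyond the scatter) and is the first pair to separate the two pyridinylmethyl groups, showing that the read-out at this position responds to which pyridine isomer is attached. The ethyl((pyridin-3-yl)methyl)amino group cannot be told apart from the piperidine-bearing chain, with a number 2.7 percentage points higher from compound 3 to compound 4 (within the scatter) even though one brings an aromatic ring and the other a non-aromatic one, whereas the ring-free dipropylamino group of compound 2 remains clearly ahead, with a number 21.3 percentage points lower from compound 2 to compound 4 (beyond the scatter) as the step away from it. No measurement at hand accounts for the size of any of these steps.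

A pyridin-4-yl group on the same chain would show whether the choice of pyridine isomer has further effect at this position. From the compounds shown here alone, it also remains open whether a dibutylamino group, with longer chains than dipropylamino, would give a higher or lower number than compound 2 does.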